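Replacing Methyl with Butylamino on a Shared Core

The compounds below may be only part of what the source reports. "The series", "measured", "known", "first", "only" and "open" are said of these compounds alone.

Compound 1 `N#Cc1cccc(C(=O)Nc2ccc3nc(NC(=O)C4CCCCC4)sc3c2)c1` — in a functional assay on WI-38 VA13 cells (Homo sapiens) for cytotoxicity (on this read-out higher numbers stand for an effect only at larger amounts of compound and lower numbers for an effect already at smaller amounts), compound 1 gives 0.52 ug/mL
Compound 2 `CCCC(C)C(=O)Nc1ccc2nc(NC(=O)C3CCCCC3)sc2c1` — compound 2 gives 0.14 ug/mL
Compound 3 `CC(=O)Nc1nc2ccc(NC(=O)c3c(Cl)cccc3Cl)cc2s1` — compound 3 gives 0.6 ug/mL

Among these three numbers compound 3 stands highest. Compound 1 lies within the scatter of compound 3, so nothing separates the two, whereas compound 2 sits beyond the scatter below compound 3. Among the compounds with values here, the only step measured so far, a 3.7-fold lower number from compound 1 to compound 2 (0.57 log units; beyond the scatter), concerns the carbonyl carbon that carries the 3-cyanophenyl or 1-methylbutyl group; it does not touch the carbonyl carbon that is altered here.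

Compound 4 `CCCCNC(=O)Nc1nc2ccc(NC(=O)c3c(Cl)cccc3Cl)cc2s1` differs from compound 3 by butylamino in place of methyl on a carbonyl carbon. Within the data shown here, no measured pair changes a group at that carbonyl carbon, so the one known step gives only a sense of how far a single exchange on this core has moved the read-out, without pointing in a direction. Compound 4 is therefore expected to stay close to compound 3, with no step beyond the scatter, which would mean a 1.2-fold lower number from compound 3 to compound 4 (0.08 log units; within the scatter). The estimate for compound 4 in this assay is 0.5 ug/mL, with a range from 0.15 ug/mL to 1.6 ug/mL.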

Compound 4, half-maximal effective concentration: 0.028 ug/mL
Compound 4: middle estimate off by 18-fold (1.25 log units), on the high side, outside the stated range (below it).
By their numbers in this assay, from the lowest: compound 4; then compound 2; then compounds 1 and 3 (each within the scatter of the next).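

In this assay, butylamino in place of methyl on a carbonyl carbon whose other neighbour is an amide-type nitrogen gives a 21-fold lower number from compound 3 to compound 4 (1.33 log units; beyond the scatter). Within the data shown here, this shows that the read-out responds strongly at this carbonyl carbon, which no earlier pair had touched; the only earlier step, a 3.7-fold lower number from compound 1 to compound 2 (0.57 log units; beyond the scatter), lay at the other carbonyl carbon and said nothing about this one. No measurement on these compounds bears on why the number falls so far at this position.

The exchange brings in the butyl chain and the nitrogen with its hydrogen together, so the compounds shown leave open which of the two carries the step, and a pentyl group, which has the chain without the nitrogen, or a shorter methylamino, which has the nitrogen without the chain, would be needed to tell them apart. Also open, on these data alone, is whether butylamino at this carbonyl carbon would lower the number to a similar extent with the other groups seen on the shared core, such as the 3-cyanophenyl of compound 1.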